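The source may hold more compounds than are shown below. What is called first, only, known or untested is meant among the compounds shown, and "the series" means these compounds.

Working notes on the series.

Compound 1, `CN1CCN(c2nc(Cl)nc3c2ncn3Cc2ccc(C(=O)Nc3ccccc3N)cc2)CC1`, gives 75% in a functional assay on HepG2 cells (Homo sapiens) for antiproliferative activity, read by CCK-8 assay, with a stated time of 72 h, tested at 8 uM (a higher number here means a stronger effect of the compound at the concentration tested, a lower number a weaker effect), the highest of the three numbers in hand. Compound 2, `Nc1ccccc1NC(=O)/C=C/c1ccc(Cn2cnc3c(NCc4ccccc4)nc(Cl)nc32)cc1`, gives 37.7%, and compound 3, `Nc1ccccc1NC(=O)c1ccc(COCNc2nc(Nc3ccc(-c4ccccc4)cc3)c3ncn(C4CCCC4)c3n2)cc1`, gives 36.2%; both sit beyond the scatter below compound 1, so compound 1 stands as the most active measured compound here.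

The next compound is compound 4, `CC1CCN(c2nc(Cl)nc3c2ncn3Cc2ccc(C(=O)Nc3ccccc3N)cc2)CC1`, which differs from compound 1 in one place: 4-methylpiperidin-1-yl in place of 4-methylpiperazin-1-yl on an aromatic carbon. For the measured compounds named here, no measured pair shows the same change, so the size of the step cannot be read from the data; the change keeps the ring size and the methyl group and loses one hydrogen-bond acceptor. Expected step from compound 1 to compound 4: a number 10 percentage points lower from compound 1 to compound 4 (within the scatter), a small drop possibly within the scatter. Compound 4 is estimated at 65%, range 40% to 85%.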

Compound 4, a percentage reported as inhibition, at one concentration (the size of the read-out at that concentration, not a potency): 65.3%
For compound 4 the middle estimate is 0.3 percentage points below the measured one, and the stated range covers the measured number.
By their numbers in this assay, from the lowest: compounds 3 and 2 (each within the scatter of the next); then compounds 4 and 1 (each within the scatter of the next).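

Placing 4-methylpiperidin-1-yl in place of 4-methylpiperazin-1-yl on the aromatic carbon gives a step in this assay of a number 9.7 percentage points lower from compound 1 to compound 4 (within the scatter). For the compounds shown here, this is the first single-place comparison, and it shows that the read-out at the tested concentration does not depend on the second ring nitrogen of the 4-methylpiperazin-1-yl group. No evidence on hand bears on this step.

Open, on these data alone, is whether morpholin-4-yl, an acyclic dimethylamino group or a piperidine carrying a carboxylic acid would stay within the scatter of compound 1. Also open, as far as these compounds go, is whether a longer chain in place of the methyl group is tolerated on either ring.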